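Aryl swap on the exocyclic piperidine alkene

The source may report more compounds than this note shows. Statements on the series, on what has been measured and on what is new or still open speak of the compounds shown alone.

Measured compounds in an assay on isolated protein for displacement of a labelled ligand from Apoptosis regulator Bcl-2 (Homo sapiens), read by fluorescence polarization; on this read-out lower numbers stand for stronger inhibition and higher numbers for weaker inhibition:
compound 1, `CCCCCC1(OC)CCN(c2ccc(C(=O)NS(=O)(=O)c3ccc(N[C@H](CCN(C)C)CSc4ccccc4)c([N+](=O)[O-])c3)cc2)CC1`: 20 nM
compound 2, `COC1(Cc2cccc(Cl)c2)CCN(c2ccc(C(=O)NS(=O)(=O)c3ccc(N[C@H](CCN(C)C)CSc4ccccc4)c([N+](=O)[O-])c3)cc2)CC1`: 1.8 nM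
compound 3, `CN(C)CC[C@H](CSc1ccccc1)Nc1ccc(S(=O)(=O)NC(=O)c2ccc(N3CCC(=Cc4ccc(F)cc4)CC3)cc2)cc1[N+](=O)[O-]`: 3.4 nM

On these three numbers compound 3 sits second highest. Its value and that of compound 2 lie within the scatter of each other, so no order between them is claimed; its value stands above that of compound 1 by more than the scatter.

Compound 4, `CN(C)CC[C@H](CSc1ccccc1)Nc1ccc(S(=O)(=O)NC(=O)c2ccc(N3CCC(=Cc4ccccc4Cl)CC3)cc2)cc1[N+](=O)[O-]`, differs from compound 3 by 2-chlorophenyl in place of 4-fluorophenyl on a double-bonded chain carbon bound to a double-bonded ring carbon. For the measured compounds named here, the only measured step, an 11-fold lower number from compound 1 to compound 2 (1.05 log units; beyond the scatter), concerns a saturated chain carbon and replaces butyl with an aryl group, whereas here one halogenated aryl group replaces another on the double-bonded chain carbon. Going by the values given here, that step therefore does not directly bear on this change, and no measured pair separates a fluorine from a chlorine or one halogen position from another. The expectation for a 1.0-fold higher number from compound 3 to compound 4 (0.01 log units; within the scatter) is accordingly a step of no size beyond the scatter. Compound 4 is expected to give about 3.5 nM, within a range of 1.2 nM to 10 nM.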

Compound 4, inhibition constant: 0.7 nM
Estimate against measurement, compound 4: 5.0-fold (0.70 log units) above, outside the stated range (below it).
By their numbers in this assay, from the lowest: compound 4; then compounds 2 and 3 (each within the scatter of the next); then compound 1.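

In this assay, the aryl group on a double-bonded chain carbon bound to a double-bonded ring carbon can move the number beyond the scatter: a 4.9-fold lower number from compound 3 to compound 4 (0.69 log units; beyond the scatter) with 2-chlorophenyl in place of 4-fluorophenyl. The heavy-atom count stays the same and no hydrogen-bond donor or acceptor enters, so the two counts do not separate these groups, yet compound 4 gives 0.7 nM and the halogenated aryl groups are not interchangeable here. Nothing available explains this difference.

Halogen identity and halogen position change together in this step, so the compounds shown cannot assign the step to either; 4-chlorophenyl and 2-fluorophenyl would separate them. Going by these compounds, how an amine or a carboxylic acid on this aryl ring would read also remains open.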